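A Trifluoromethyl Group on Compound 1

The source may hold more compounds than are shown below. What is called first, only, known or untested is meant among the compounds shown, and "the series" means these compounds.

Compound 1 `Cn1nc(-c2ccccc2)c2c1OC(N)=C(C#N)C2c1ccccc1`: > 10000 nM
Compound 2 `Cn1nc(-c2ccccc2)c2c1OC(N)=C(C#N)C2c1cc(F)cc(F)c1`: 6600 nM
Compound 3 `COc1ccc(C2C(C#N)=C(N)Oc3c2c(-c2ccccc2)nn3C)cc1F`: > 10000 nM

In a functional assay on NCI-H2122 cells (Homo sapiens) for inhibition, read by microscopy, with a stated time of 10 days (a higher number here means a weaker inhibitor, a lower number a stronger inhibitor), compound 1 gives > 10000 nM, which is a limit of the assay and not a number. Compound 3 gives > 10000 nM, also a limit. Compound 4 `Cn1nc(-c2ccccc2)c2c1OC(N)=C(C#N)C2c1ccc(C(F)(F)F)cc1` differs from compound 1 by trifluoromethyl in place of hydrogen on an aromatic carbon, para to a large group: trifluoromethyl in place of hydrogen on an aromatic carbon. Two measured steps also alter that phenyl: an at least 1.5-fold lower number from compound 1 to compound 2 (0.18 log units; that floor lies within the scatter), and a step that the two limits leave unreadable from compound 1 to compound 3. Neither step is shown to exceed the scatter, so no change beyond the scatter is expected in this assay. The estimated step is a number no higher from compound 1 to compound 4 (the limit leaves the size open). The expected value for compound 4 is 10000 nM. The expected range for compound 4 runs from 4000 nM to 25000 nM.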

Compound 4, half-maximal inhibitory concentration: 4100 nM
The estimate for compound 4 lay 2.4-fold (0.39 log units) above the measured number; the measured number falls inside the stated range.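

In this assay the change gives an at least 2.4-fold lower number from compound 1 to compound 4 (0.38 log units; beyond the scatter), the first step on this phenyl shown to lie beyond the scatter. A single trifluoromethyl on an aromatic carbon, para to a large group, is therefore enough to give a readable change on the shared core. The true size of the step stays open, since the value of compound 1 is a limit of the assay and not a number: the limit of > 10000 nM in this assay, at which 2 of the 4 values shown sit.

As far as these compounds go, whether a methyl, a chlorine or an amine on this carbon would do the same stays open. So does what trifluoromethyl would do on another carbon of this ring.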